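The source may hold more compounds than are shown below. What is called first, only, known or untested is meant among the compounds shown, and "the series" means these compounds.

Measured so far in an assay on isolated protein for inhibition of Thymidylate synthase (Mus musculus); on this read-out lower numbers stand for stronger inhibition and higher numbers for weaker inhibition:
compound 1 `Cc1nc2ccc(CNc3ccc(C(=O)N[C@@H](CCC(=O)O)C(=O)O)cc3F)cc2c(=O)[nH]1` gives 9340 nM
compound 2 `Cc1nc2ccc(CN(CCN)c3ccc(C(=O)N[C@@H](CCC(=O)O)C(=O)O)c(F)c3)cc2c(=O)[nH]1` gives 11700 nM
compound 3 `CCN(Cc1ccc2nc(C)[nH]c(=O)c2c1)c1ccc(C(=O)N[C@@H](CCC(=O)O)C(=O)O)c(F)c1` gives 45 nM

Compound 1 stands second highest of the three numbers; compound 2 lies within the scatter of it, and compound 3 lies far lower than both.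

The unmeasured compound 4 `C#CCN(Cc1ccc2nc(C)[nH]c(=O)c2c1)c1ccc(C(=O)N[C@@H](CCC(=O)O)C(=O)O)cc1F` differs from compound 1 in one place: propargyl in place of hydrogen on a nitrogen on an aromatic ring. Among the measured compounds shown here, no measured step covers exactly this change. For the measured compounds named here, the only step, a 260-fold lower number from compound 2 to compound 3 (2.41 log units; beyond the scatter), is a large one and concerns what sits on the saturated chain carbon attached to the same kind of nitrogen, not the nitrogen itself. Compound 1 and compound 3 differ in two places, the group on the nitrogen and where the fluorine sits, so their values can only be compared as such: the compound with an ethyl on the nitrogen sits far lower than the one with a hydrogen there. Compound 2, which also carries a substituent on the nitrogen, stays high, so a substituent alone does not settle the matter; the amino on its chain is the one thing shown to matter.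

Given that compound 3 reaches 45 nM with a plain alkyl on the nitrogen and no amino, compound 4 is expected to move in the same direction, with a step estimated at a 160-fold lower number from compound 1 to compound 4 (2.19 log units; beyond the scatter). The estimate for compound 4 is 60 nM, with a range from 15 nM to 300 nM, the width reflecting that the change is not matched by any measured step.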

Compound 4, half-maximal inhibitory concentration: 1430 nM
Estimate against measurement, compound 4: 24-fold (1.38 log units) below; the whole stated range lies below it.
By their numbers in this assay, from the lowest: compound 3; then compound 4; then compounds 1 and 2 (each within the scatter of the next).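

In this assay, propargyl in place of hydrogen on a nitrogen on an aromatic ring gives a 6.5-fold lower number from compound 1 to compound 4 (0.82 log units; beyond the scatter), the first matched read on this nitrogen itself. The earlier step, a 260-fold lower number from compound 2 to compound 3 (2.41 log units; beyond the scatter), concerned only what sits on the saturated chain carbon; this pair shows that the hydrogen on the nitrogen can be replaced by a group of 3 carbon atoms with a triple bond, and that the number then falls beyond the scatter, though the step is only modest in size. No measurement on hand accounts for this drop, so its cause stays unassigned.

As far as these compounds go, compound 3 and compound 4 differ in both the group on the nitrogen and where the fluorine sits, so the share of each in their printed values remains open. A propyl group on the same nitrogen would show whether the triple bond of propargyl counts at all, and a pair carrying propargyl with the fluorine placed as in compound 3 would show what the fluorine position contributes on its own.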